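Capping the aniline of compound 2 with a bromoacrylamide

A few compounds are considered here, and "the series" means these few. Any claim that something is new, unique, unknown or untested is made for them only; others in the source may bear on it.

The series rests on two measured compounds. Compound 1 `C=C(Br)C(=O)Nc1cccc(-c2cn3nc(Cc4ccc(Cl)cc4)sc3n2)c1` gives 1100 nM in a functional assay on FM3A cells (Mus musculus) for inhibition, read by cell counting, with a stated time of 2 days; on this read-out higher numbers stand for weaker inhibition and lower numbers for stronger inhibition. Compound 2 `COc1ccc(-c2nn3cc(-c4cccc(N)c4)nc3s2)cc1OC` gives 13000 nM in this assay, the highest number of the two, and its gap to compound 1, the nearest compound, lies beyond the usual scatter. Compound 3 `C=C(Br)C(=O)Nc1cccc(-c2cn3nc(-c4ccc(OC)c(OC)c4)sc3n2)c1` differs from compound 2 by (1-bromoethenyl)carbonyl in place of hydrogen on a nitrogen on an aromatic ring, the amino group of compound 2 becoming a ((1-bromoethenyl)carbonyl)amino group. Among the compounds with values here, no measured pair shows this change in isolation, but compound 1 carries the same ((1-bromoethenyl)carbonyl)amino group and gives 1100 nM, a lower number than compound 2. The author therefore expects compound 3 to move toward stronger inhibition in this assay, by a step of a 4.3-fold lower number from compound 2 to compound 3 (0.64 log units; beyond the scatter) from compound 2 to compound 3 that should exceed the scatter. The estimate for compound 3 in this assay is 3000 nM, within a range of 800 nM to 12000 nM.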

Compound 3, half-maximal inhibitory concentration: 110 nM
Compound 3: middle estimate off by 27-fold (1.44 log units), on the high side, and the stated range ends above it.
By their numbers in this assay, from the lowest: compound 3; then compound 1; then compound 2.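

In this assay, (1-bromoethenyl)carbonyl in place of hydrogen on a nitrogen on an aromatic ring gives a 120-fold lower number from compound 2 to compound 3 (2.07 log units; beyond the scatter) and this is the only pair shown that isolates the change, which proves large on this nitrogen. With the ((1-bromoethenyl)carbonyl)amino group held constant, 3,4-dimethoxyphenyl in place of 4-chlorobenzyl on an aromatic carbon gives a 10-fold lower number from compound 1 to compound 3 (1.00 log units; beyond the scatter) and so shows that this second position also affects the read-out, by a modest step. Nothing shown accounts for either step.

From the compounds shown here alone, it remains open whether a plain acrylamide or an acetamide on the same nitrogen would give a step of similar size, which leaves the part played by the bromine unsettled. Going by these compounds, it also remains open whether the change at the nitrogen would be as large with 4-chlorobenzyl on the core.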